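Replacing Dimethoxy with Dihydroxy Across Two Related Series

This account rests on a few compounds, and the source may have more. Where it says the series, first, only, none or still open, it means among the compounds named here.

In a functional assay on HeLa cells (Homo sapiens) for inhibition, read by CCK-8 assay, with a stated time of 48 h (on this read-out lower numbers stand for stronger inhibition and higher numbers for weaker inhibition), compound 1 `COc1ccc(Oc2ccc(C(C)C)cc2-c2ccsc2S(=O)(=O)NCCNC(=S)Nc2ccc([N+](=O)[O-])cc2)cc1OC` gives 11900 nM. Compound 2 `CC(C)c1ccc(Oc2ccc(O)c(O)c2)c(-c2ccsc2S(=O)(=O)NCCNC(=S)Nc2ccc([N+](=O)[O-])cc2)c1` carries 3,4-dihydroxyphenyl in place of 3,4-dimethoxyphenyl on an oxygen on an aromatic ring. For compound 2 this assay reports only a limit, > 20000 nM. That change gave an at least 1.6-fold higher number from compound 1 to compound 2 (0.22 log units; that floor lies within the scatter), a floor set by the limit of > 20000 nM in this assay, at which 1 of the 3 values shown sits. Compound 3 `COc1ccc(Oc2ccccc2-c2ccsc2S(=O)(=O)N2CCN(C(=S)Nc3cc(C(F)(F)F)cc(C(F)(F)F)c3)CC2)cc1OC` and compound 4 `O=S(=O)(c1sccc1-c1ccccc1Oc1ccc(O)c(O)c1)N1CCN(C(=S)Nc2cc(C(F)(F)F)cc(C(F)(F)F)c2)CC1` are linked by the same change, namely (3,4-dihydroxyphenyl in place of 3,4-dimethoxyphenyl on an oxygen on an aromatic ring); the difference between the cores of compound 1 and compound 3 is not broken down here. For compound 3 this assay again reports only a limit, > 50000 nM, which is the limit of > 50000 nM in this assay, at which 1 of the 3 values shown sits. Since compound 3 already sits at a limit and the same change elsewhere produced an at least 1.6-fold higher number from compound 1 to compound 2 (0.22 log units; that floor lies within the scatter), compound 4 is expected to remain at or beyond that limit, a step estimated at a step that the limit leaves unreadable from compound 3 to compound 4. The estimate for compound 4 is 80000 nM, expected between 30000 nM and 300000 nM.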

Compound 4, half-maximal inhibitory concentration: > 20000 nM
Compound 4: a limit, no number (the forecaster's own chance of this, stated with the estimate: 85%); the middle value is on the limit's open side.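

Compound 3 and compound 4 both stand only as limits, and the step between them cannot be read. The compounds shown leave open how far 3,4-dihydroxyphenyl in place of 3,4-dimethoxyphenyl changes inhibition in either series.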